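Swapping the Aryl Arm for a Phenylsulfanyl Group

A few compounds are considered here, and "the series" means these few. Any claim that something is new, unique, unknown or untested is made for them only; others in the source may bear on it.

Three compounds have been measured in a functional assay on Jurkat cells for inhibition of nuclear factor NF-kappa-B complex (Homo sapiens); a higher number here means a weaker inhibitor, a lower number a stronger inhibitor:
- compound 1 `CCOC(=O)c1cnc(-c2ccncc2)nc1NN1C(=O)C=C(C)C1=O` gives 6000 nM
- compound 2 `CCOC(=O)c1cnc(-c2cnc3ccccc3c2)nc1NN1C(=O)C=C(C)C1=O` gives 6000 nM
- compound 3 `CCOC(=O)c1cnc(-c2ccc(C)s2)nc1NN1C(=O)C=C(C)C1=O` gives 200 nM

Compound 3 stands lowest of the three numbers in this assay, and its steps to the other two are both beyond the scatter: a 30-fold lower number from compound 1 to compound 3 (1.48 log units; beyond the scatter) and a 30-fold lower number from compound 2 to compound 3 (1.48 log units; beyond the scatter). The two nitrogen-containing aryl groups, by contrast, sit within the scatter of each other, no change at the digits printed from compound 1 to compound 2 (within the scatter).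

Compound 4 `CCOC(=O)c1cnc(Sc2ccccc2)nc1NN1C(=O)C=C(C)C1=O` has not yet been measured. It differs from compound 3 in one place: phenylsulfanyl in place of 5-methylthiophen-2-yl on an aromatic carbon. Going by the values given here, none of the measured steps exchanges an aryl group for a sulfur-linked one, so no step bears directly on this change. What the measured steps do show is that the identity of the group at this position can move the number a great deal, and that only the 5-methylthiophen-2-yl group gave the low number seen for compound 3. The account therefore expects the number for compound 4 to rise from that of compound 3 by a 7.5-fold higher number from compound 3 to compound 4 (0.88 log units; beyond the scatter), with wide uncertainty. The estimate for compound 4 in this assay is 1500 nM, expected to fall between 200 nM and 10000 nM.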

Compound 4, half-maximal inhibitory concentration: 1000 nM
The estimate for compound 4 lay 1.5-fold (0.18 log units) above the measured number; low and high end bracket the measured number.
By their numbers in this assay, from the lowest: compound 3; then compound 4; then compounds 1 and 2 (each within the scatter of the next).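

In this assay the phenylsulfanyl arm, on the aromatic carbon between two ring nitrogen atoms, gives a 6.0-fold lower number from compound 1 to compound 4 (0.78 log units; beyond the scatter) and a 6.0-fold lower number from compound 2 to compound 4 (0.78 log units; beyond the scatter) but also a 5.0-fold higher number from compound 3 to compound 4 (0.70 log units; beyond the scatter) and so lands on neither of the earlier levels. This shows that the low numbers at this position are not confined to 5-methylthiophen-2-yl and that an arm joined through sulfur can be carried here. Across these four compounds the two arms with no ring nitrogen give lower numbers than the two arms with one, and no compound shown goes against this, although the set is small and no measurement beyond these numbers helps to explain it.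

From the compounds shown here alone, compound 4 changes the ring and the way it is attached in a single step, so the share of each in the result stays open: a phenyl ring joined directly, a phenoxy arm or an anilino arm would pull the two apart. Going by these compounds, the part played by the methyl on the thiophene also remains open, and an unsubstituted thiophen-2-yl group would speak to it.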